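The compounds below may be only part of what the source reports. "The series", "measured", "known", "first", "only" and "open" are said of these compounds alone.

Measured in a functional assay on the whole organism for inhibition, with Cavia porcellus as the target; on this read-out higher numbers stand for an effect only at larger amounts of compound and lower numbers for an effect already at smaller amounts:
- compound 1 `COc1ccccc1OCC1SCCN1C(=O)CN`: 57 mg/kg
- compound 2 `CCCC(=O)CC(=O)N1CCSC1COc1ccccc1OC`: 42 mg/kg
- compound 3 `CCOC(=O)CCC(=O)N1CCSC1COc1ccccc1OC`: 24 mg/kg

In this assay, compound 2 at 42 mg/kg lies within the scatter of both other compounds. Only the outer pair is separated beyond the scatter, by a 2.4-fold lower number from compound 1 to compound 3 (0.38 log units; beyond the scatter).

Compound 4 `COc1ccccc1OCC1SCCN1C(=O)CC(=O)NCc1cccnc1` comes from compound 2 by placing ((pyridin-3-yl)methyl)amino in place of propyl on a carbonyl carbon.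

Among the measured compounds shown here, no measured compound carries this group, and no measured step acts on the carbonyl carbon itself. The closest evidence is the three steps on a saturated chain carbon bound to a carbonyl carbon. These are a 1.4-fold lower number from compound 1 to compound 2 (0.13 log units; within the scatter), a 1.8-fold lower number from compound 2 to compound 3 (0.24 log units; within the scatter) and the modest 2.4-fold lower number from compound 1 to compound 3 (0.38 log units; beyond the scatter). All are small, so the structural change is not expected to move the number beyond the scatter, and no direction can be argued with confidence.

The expected move is a 1.2-fold lower number from compound 2 to compound 4 (0.08 log units; within the scatter).

For compound 4 the estimate is 35 mg/kg, with an expected range of 15 mg/kg to 80 mg/kg.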

Compound 4, dose for half-maximal effect: 57 mg/kg
Compound 4: middle estimate off by 1.6-fold (0.21 log units), on the low side, within the range that was stated.
By their numbers in this assay, from the lowest: compounds 3, 2, 1 and 4 (each within the scatter of the next, the first and the last beyond it).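

Among the compounds shown here, putting ((pyridin-3-yl)methyl)amino in place of propyl on a carbonyl carbon gives a 1.4-fold higher number from compound 2 to compound 4 (0.13 log units; within the scatter) in this assay and is the first step in this set that acts on the carbonyl carbon itself. The number stays within the scatter even though the entering group brings a six-membered aromatic ring and a hydrogen-bond donor, neither of which propyl carries, so this one step shows that such a change here need not shift the read-out beyond the scatter. Nothing available offers an explanation for this result.

Still open, as far as these compounds go, is what the six-membered aromatic ring's nitrogen contributes, which benzylamino on the same carbonyl carbon would separate from the rest of the change. Also open, from the compounds shown here alone, is whether hydroxy at that carbon, giving a carboxylic acid, or a longer chain in place of propyl would move the number beyond the scatter.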